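Chloro to Methoxy: What to Expect for Compound 4

This account rests on a few compounds, and the source may have more. Where it says the series, first, only, none or still open, it means among the compounds named here.

Compound 1 `COc1ccc(-c2nc(SCC(=O)c3sc(-c4ccccc4)nc3C)[nH]c(=O)c2C#N)cc1` gives 90.4% in a functional assay on U-87MG ATCC cells for antiproliferative activity against U-87 MG (Homo sapiens), read by MTT assay, with a stated time of 48 h, tested at 10 uM; on this read-out lower numbers stand for a stronger effect and higher numbers for a weaker effect at the one concentration tested.
Compound 2 `Cc1nc(-c2ccc(Cl)cc2)sc1C(=O)CSc1nc(N)c(C#N)c(-c2ccc(Cl)cc2)n1` gives 37.3% in this assay.
Compound 3 `Cc1nc(-c2ccccc2)sc1C(=O)CSc1nc(-c2ccc(Cl)cc2)c(C#N)c(=O)[nH]1` gives 85.2% in this assay.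

Compound 2 stands lowest, and its gaps to compound 3 and compound 1 both lie beyond the usual scatter. Compound 3 and compound 1 differ only by methoxy in place of chloro on an aromatic carbon, and that change moved the read-out by a number 5.2 percentage points higher from compound 3 to compound 1 (within the scatter), a shift within the scatter.

Compound 4 `COc1ccc(-c2nc(SCC(=O)c3sc(-c4ccc(Cl)cc4)nc3C)nc(N)c2C#N)cc1` has not yet been measured. It differs from compound 2 by methoxy in place of chloro on an aromatic carbon, the same change at the same place. How the core of compound 2 differs from the core of compound 3 is not broken down here.

Because the earlier step was a number 5.2 percentage points higher from compound 3 to compound 1 (within the scatter), the step from compound 2 to compound 4 is expected to be small, about a number 5.7 percentage points higher from compound 2 to compound 4 (within the scatter). Compound 4 is therefore estimated at 43%, likely between 25% and 65%.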

Compound 4, a percentage reported as activity, at one concentration (the size of the read-out at that concentration, not a potency): 64.5%
For compound 4 the middle estimate is 21.5 percentage points below the measured one; the measured number falls inside the stated range.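

In this assay, putting methoxy in place of chloro on the core of compound 2 gave a number 27.2 percentage points higher from compound 2 to compound 4 (beyond the scatter), which means a weaker effect at the one concentration tested. In this series, the size of the step therefore did not carry over from one core to the other: the same change on two cores in this assay, a number 5.2 percentage points higher (within the scatter) from compound 3 to compound 1 and a number 27.2 percentage points higher (beyond the scatter) from compound 2 to compound 4, 22 percentage points apart, beyond the scatter of two such steps

For the compounds shown here, this comparison rests on only two pairs, and these pairs differ from each other in more than one place, so it does not show which part of the core sets the size of the step. The compounds shown leave open how a hydroxy or a dimethylamino group would behave in place of the methoxy on either core.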